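From methyl to methoxy: compound 3 to compound 4

A few compounds are considered here, and "the series" means these few. Any claim that something is new, unique, unknown or untested is made for them only; others in the source may bear on it.

Compound 1 `Cc1cccc(F)c1-c1nc(CN2CCC(C(=O)NCCCN3C[C@H](C)C[C@H](C)C3)CC2)c(C)o1` gives 0.0733 h
Compound 2 `COc1cccc(Br)c1-c1nc(CN2CCC(C(=O)NCCCN3C[C@H](C)C[C@H](C)C3)CC2)c(C)o1` gives 0.0583 h
Compound 3 `COc1cccc(C)c1-c1nc(CN2CCC(C(=O)NCCCN3C[C@H](C)C[C@H](C)C3)CC2)c(C)o1` gives 0.0767 h

In an ADME assay on microsomes from liver (Rattus norvegicus) for metabolic stability, read by LC-MS, using NADPH, at 37 degrees C (a lower number here means that the compound disappears faster, a higher number that the compound lasts longer), compound 3 at 0.0767 h cannot be told apart from compound 1 or compound 2 given the usual scatter. Compound 4 `COc1cccc(OC)c1-c1nc(CN2CCC(C(=O)NCCCN3C[C@H](C)C[C@H](C)C3)CC2)c(C)o1` changes one place: methoxy in place of methyl on an aromatic carbon puts methoxy in place of methyl on an aromatic carbon. This exact swap has not been measured. The closest evidence is a 1.0-fold higher number from compound 1 to compound 3 (0.02 log units; within the scatter) for methoxy in place of fluoro and a 1.3-fold higher number from compound 2 to compound 3 (0.12 log units; within the scatter) for methyl in place of bromo, and a 1.3-fold lower number from compound 1 to compound 2 (0.10 log units; within the scatter) adds a third small step. With all three steps inside the scatter, no step beyond it is expected in this assay here. a 1.1-fold lower number from compound 3 to compound 4 (0.04 log units; within the scatter) is the expected step. Compound 4 is estimated at 0.07 h with an expected range of 0.045 h to 0.11 h for repeated measurements.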

Compound 4, half-life: 0.2 h
The estimate for compound 4 lay 2.9-fold (0.46 log units) below the measured number; measured number outside the range, above it.
By their numbers in this assay, from the lowest: compounds 2, 1 and 3 (each within the scatter of the next); then compound 4.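

In this assay, this position can shift the half-life beyond the scatter after all: methoxy in place of methyl gives the clearest view (a 2.6-fold higher number from compound 3 to compound 4 (0.42 log units; beyond the scatter)), and the same rise appears against the bromo compound (a 3.4-fold higher number from compound 2 to compound 4 (0.54 log units; beyond the scatter)) and the fluoro-methyl compound (a 2.7-fold higher number from compound 1 to compound 4 (0.44 log units; beyond the scatter)). A single methoxy, as in compound 2 and compound 3, left the number within the scatter of compound 1, so the rise appears only with the 2,6-dimethoxyphenyl group. Nothing given here explains this rise.

From the compounds shown here alone, whether a larger chain such as ethoxy, or an amine, in place of the methoxy would keep the longer half-life remains open.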